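The compounds below may be only part of what the source reports. "The series", "measured", "known", "first", "only" and "open" are said of these compounds alone.

Measured compounds:
Compound 1, `CCOC(=O)c1cnc(-c2cccc(OC)c2)nc1NN1C(=O)C=C(C)C1=O`: 5000 nM
Compound 2, `CCOC(=O)c1cnc(-c2ccc(Cl)cc2)nc1NN1C(=O)C=C(C)C1=O`: 300 nM

Both compounds share one core and differ only in the aryl group attached to it. Among the measured compounds shown here, in a functional assay on Jurkat cells for inhibition of nuclear factor NF-kappa-B complex (Homo sapiens) (on this read-out lower numbers stand for stronger inhibition and higher numbers for weaker inhibition), compound 1 gives 5000 nM, while compound 2 gives 300 nM, which is the lowest of the two numbers on hand; the only measured step, a 17-fold lower number from compound 1 to compound 2 (1.22 log units; beyond the scatter), is large and lies well beyond the scatter, so compound 2 stands clearly apart from compound 1.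

Compound 3, `CCOC(=O)c1cnc(-c2cc3ccccc3s2)nc1NN1C(=O)C=C(C)C1=O`, has not yet been measured in this assay. Its change from compound 2 is 1-benzothiophen-2-yl in place of 4-chlorophenyl on an aromatic carbon. For the measured compounds named here, no measured step bears directly on this exchange: the one step available, a 17-fold lower number from compound 1 to compound 2 (1.22 log units; beyond the scatter), shows only that the aryl group at this position can move the number a great deal, without saying which way a bicyclic group would push it.

Compound 3 is therefore expected to sit near compound 2, with a wide range, namely 600 nM (100 nM to 4000 nM), a step of a 2.0-fold higher number from compound 2 to compound 3 (0.30 log units; within the scatter) that is estimated, not yet known.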

Compound 3, half-maximal inhibitory concentration: 4000 nM
For compound 3 the middle estimate is 6.7-fold (0.82 log units) below the measured one, within the range that was stated.
By their numbers in this assay, from the lowest: compound 2; then compounds 3 and 1 (each within the scatter of the next).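

In this assay the exchange of 4-chlorophenyl for 1-benzothiophen-2-yl gives a 13-fold higher number from compound 2 to compound 3 (1.12 log units; beyond the scatter) and so shows that the low number of compound 2 does not carry over to an aryl group with two aromatic rings, one of them holding sulfur. The second comparison, a 1.3-fold lower number from compound 1 to compound 3 (0.10 log units; within the scatter), lies within the scatter, so 1-benzothiophen-2-yl and 3-methoxyphenyl cannot be told apart on this read-out, even though they share little beyond being aromatic. Among the three aryl groups shown, only 4-chlorophenyl stands clear of the others, and the position on the shared core, between two ring nitrogen atoms, therefore tolerates some aryl groups far better than others.

The compounds shown leave open whether the chlorine itself matters, which an unsubstituted phenyl group, or a bromine or a methyl group in its place, would help to settle. They also leave open how the ethoxycarbonyl group contributes, for instance whether a carboxylic acid or an amide there would keep the number of compound 2. Nothing at hand accounts for the size of these steps.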